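This account rests on a few compounds, and the source may have more. Where it says the series, first, only, none or still open, it means among the compounds named here.

Measured so far:
Compound 1, `Cc1n[nH]c2ccc(-c3nc4cnc(N5CCN(C)CC5)cn4c3Nc3ccccc3Cl)cc12`, gives 58.1%.
Compound 2, `Cc1n[nH]c2ccc(-c3nc4cnc(N5CCN(C)CC5)cn4c3Nc3ccc(Cl)cc3F)cc12`, gives 0%.

In a functional assay on MV4-11 cells (Homo sapiens) for inhibition, with a stated time of 120 h, tested at 10 uM (a lower number here means less inhibition, a higher number more inhibition at the concentration tested (going by the name of the read-out)), compound 2 stands lowest of the two numbers; its nearest neighbour is compound 1, and the step of a number 58.1 percentage points lower from compound 1 to compound 2 (beyond the scatter) separates them. Compound 3, `Cc1n[nH]c2ccc(-c3nc4cnc(N5CCN(C)CC5)cn4c3Nc3ccc(Br)cc3Cl)cc12`, is not yet measured. It differs from compound 2 by 4-bromo-2-chlorophenyl in place of 4-chloro-2-fluorophenyl on a nitrogen on an aromatic ring. Going by the values given here, the only measured step at this place is a number 58.1 percentage points lower from compound 1 to compound 2 (beyond the scatter), a large loss on going from 2-chlorophenyl to 4-chloro-2-fluorophenyl. Compound 3 keeps a halogen in both places of the ring as in compound 2, but with chlorine where compound 2 carries fluorine, as in compound 1. Among the compounds with values here, no measured step shows that exchange alone, so the outcome is uncertain. A partial recovery is expected, with the step of a number 20 percentage points higher from compound 2 to compound 3 (beyond the scatter) estimated to be modest. Compound 3 is thus estimated at 20%, within a range from 0% to 55%.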

Compound 3, a percentage reported as inhibition, at one concentration (the size of the read-out at that concentration, not a potency): 70.5%
The estimate for compound 3 lay 50.5 percentage points below the measured number, and the stated range ends below it.
By their numbers in this assay, from the lowest: compound 2; then compound 1; then compound 3.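

In this assay the change to 4-bromo-2-chlorophenyl on the nitrogen gives a number 70.5 percentage points higher from compound 2 to compound 3 (beyond the scatter) and so shows that this position is not closed to a phenyl group with two halogens. The step of a number 12.4 percentage points higher from compound 1 to compound 3 (beyond the scatter) for bromo in place of hydrogen on an aromatic carbon shows that the 2-chlorophenyl group keeps its inhibition with this added halogen, so the loss seen with compound 2 does not follow from having a second halogen as such. Nothing measured here gives a cause for either step.

Since both halogens change together between compound 2 and compound 3, the compounds shown do not separate the part each exchange plays. Going by these compounds, it also stays open how a methoxy group or an amine would fare in place of the bromo.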